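A few compounds are considered here, and "the series" means these few. Any claim that something is new, unique, unknown or untested is made for them only; others in the source may bear on it.

Working notes on the series. Three compounds have been run in a functional assay on A549 cells (Homo sapiens) for cytotoxicity, read by colorimetric assay and MTT assay, with a stated time of 3 days, tested at 20 uM; a lower number here means a stronger effect, a higher number a weaker effect of the compound at the concentration tested. Compound 1 `O=C1COc2ccc(-c3[nH]c(-c4ccc(F)cc4)nc3-c3ccccc3)cc2N1` gives 37.5%. Compound 2 `O=C1COc2ccc(-c3nn(-c4ccc(Cl)cc4)cc3-c3ccccc3)cc2N1` gives 52.4%. Compound 3 `O=C1COc2ccc(-c3[nH]c(-c4ccc(Cl)cc4Cl)nc3-c3ccccc3)cc2N1` gives 68.3%. On these numbers compound 2 stands second highest of the three, between compound 1 below it and compound 3 above it, both gaps beyond the scatter. Within the data shown here, the one step computed within the set is a number 30.8 percentage points higher from compound 1 to compound 3 (beyond the scatter), a large step on an aromatic carbon of the core of compound 1.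

Compound 4 `Cc1ccccc1-n1cc(-c2ccccc2)c(-c2ccc3c(c2)NC(=O)CO3)n1` has not yet been run in this assay. It differs from compound 2 in one place: 2-methylphenyl in place of 4-chlorophenyl on an aromatic nitrogen. Among the measured compounds shown here, no measured step touches an aromatic nitrogen, and the one step known lies on another core and swaps halogen-bearing phenyls; it gives only a loose sense of how much a change at a phenyl on this scaffold can move the number. A step not beyond the scatter is expected from compound 2 to compound 4, a number 2.6 percentage points higher from compound 2 to compound 4 (within the scatter). Compound 4 is therefore estimated at 55%, within 35% to 75%.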

Compound 4, a percentage reported as activity, at one concentration (the size of the read-out at that concentration, not a potency): 85.3%
Compound 4: the middle estimate sits 30.3 percentage points below what was measured; measured number above the stated range.
By their numbers in this assay, from the lowest: compound 1; then compound 2; then compound 3; then compound 4.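

The aromatic nitrogen of the five-membered ring is now shown to be a sensitive place in this assay: 2-methylphenyl in place of 4-chlorophenyl gives a number 32.9 percentage points higher from compound 2 to compound 4 (beyond the scatter) and is a large step at a position no earlier pair touched. The leaving and entering groups have the same heavy-atom count, each with one six-membered aromatic ring of carbon only and no hydrogen-bond donors or acceptors, so these counts do not separate compound 2 from compound 4, although the read-out does. Nothing available explains the size of this step.

The pair changes the chlorine, the methyl and the place of the substituent on the phenyl at once, so 4-methylphenyl and 2-chlorophenyl would be needed to separate these changes. As far as these compounds go, how an amine or a carboxylic acid on this phenyl would read remains open.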